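A few compounds are considered here, and "the series" means these few. Any claim that something is new, unique, unknown or untested is made for them only; others in the source may bear on it.

Working notes on the series

Compound 1 `COc1cccc(C(=O)N2CCN(CC(=O)N3CCN(CCCc4c[nH]c5ccccc45)CC3)CC2)c1` carries a methoxy group on its phenyl ring and an unsubstituted indole. In an ADME assay on SH-SY5Y cells (Homo sapiens) for cytotoxicity, read by MTT assay, with a stated time of 72 h (on this read-out lower numbers stand for stronger inhibition and higher numbers for weaker inhibition), compound 1 returns only a limit of the assay, > 200000 nM. Compound 2 `O=C(CN1CCN(C(=O)c2cccc(Br)c2)CC1)N1CCN(CCCc2c[nH]c3ccccc23)CC1` differs from compound 1 by bromo in place of methoxy on an aromatic carbon; in this assay compound 2 gives 80500 nM, which is an at least 2.4-fold lower number from compound 1 to compound 2 (0.39 log units; beyond the scatter). Because compound 1 sits at the limit of > 200000 nM in this assay, at which 1 of the 3 values shown sits, the true size of that step is not fixed, only its floor. Compound 3 `COc1cccc(C(=O)N2CCN(CC(=O)N3CCN(CCCc4c[nH]c5ccc(F)cc45)CC3)CC2)c1` differs from compound 1 by fluoro in place of hydrogen on an aromatic carbon, and in this assay compound 3 gives 79400 nM, a step of an at least 2.5-fold lower number from compound 1 to compound 3 (0.40 log units; beyond the scatter). Compound 2 and compound 3 lie within the scatter of each other, so no order between them can be read.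

Compound 4 `O=C(CN1CCN(C(=O)c2cccc(Br)c2)CC1)N1CCN(CCCc2c[nH]c3ccc(F)cc23)CC1` is not yet measured. It differs from compound 3 by bromo in place of methoxy on an aromatic carbon. Among the compounds with values here, this is the same change as the one from compound 1 to compound 2: the place lines match word for word, and the cores differ only by fluoro in place of hydrogen on an aromatic carbon. If the bromo-for-methoxy change carries over onto the fluoro-bearing core, an estimated step of a 2.6-fold lower number from compound 3 to compound 4 (0.42 log units; beyond the scatter) is expected from compound 3 to compound 4, resting on the step of an at least 2.4-fold lower number from compound 1 to compound 2 (0.39 log units; beyond the scatter), whose floor is all that compound 1 allows to be seen. Compound 4 is therefore estimated at 30000 nM in this assay, with an expected range from 10000 nM to 80000 nM.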

Compound 4, half-maximal inhibitory concentration: 71600 nM
Beside the measured number, compound 4's estimate is 2.4-fold (0.38 log units) below it; low and high end bracket the measured number.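

On the fluoro-bearing core, bromo in place of methoxy gives a 1.1-fold lower number from compound 3 to compound 4 (0.04 log units; within the scatter), and on the bromo-bearing core, fluoro in place of hydrogen gives a 1.1-fold lower number from compound 2 to compound 4 (0.05 log units; within the scatter), so in this assay neither change shifts the number beyond the scatter when the other is already present. This does not show that the bromo-for-methoxy change behaves differently on the two cores, nor that it carries over unchanged: the same change on two cores in this assay, an at least 2.4-fold lower number (0.39 log units; beyond the scatter) from compound 1 to compound 2 and a 1.1-fold lower number (0.04 log units; within the scatter) from compound 3 to compound 4; the limit leaves it open whether they differ. The fluoro-for-hydrogen change stands in the same position, with neither a difference between cores nor a transfer established: the same change on two cores in this assay, an at least 2.5-fold lower number (0.40 log units; beyond the scatter) from compound 1 to compound 3 and a 1.1-fold lower number (0.05 log units; within the scatter) from compound 2 to compound 4; the limit leaves it open whether they differ.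

The compounds shown leave open the true size of both steps out of compound 1, and so whether either change has any effect on that core that is absent on the other cores. They also leave open how the series responds in this assay to a carboxylic acid or an amine in place of the bromo, or to a longer chain in place of the one carrying the indole, since the four compounds cover only methoxy against bromo and hydrogen against fluoro.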